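Closing the Ring, Opening the Acid: A Third Amide Substituent

The source may hold more compounds than are shown below. What is called first, only, known or untested is meant among the compounds shown, and "the series" means these compounds.

Measured compounds:
- compound 1 `CCCCCCCCCCCC(=O)OC[C@H](CSC[C@@H](N)C(=O)NCCO)OC(=O)CCCCCCCCCCC`: 24 nM
- compound 2 `CCCCCCCCCCCC(=O)OC[C@H](CSC[C@@H](N)C(=O)NC(C)CCc1ccccc1)OC(=O)CCCCCCCCCCC`: 160 nM

Both compounds share one core, a cysteine carrying two long fatty ester chains, and differ only in the group on the amide-type nitrogen. In an assay on HEK293 cells for agonist activity at Toll-like receptor 2 (Homo sapiens) (a lower number here means that less compound is needed, a higher number that more compound is needed for the effect), compound 1 gives 24 nM, while compound 2 gives 160 nM. Compound 2 therefore stands at the higher of the two numbers: the step of a 6.7-fold higher number from compound 1 to compound 2 (0.82 log units; beyond the scatter) shows that swapping the small 2-hydroxyethyl for the bulkier 1-methyl-3-phenylpropyl needed more compound.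

Compound 3 `CCCCCCCCCCCC(=O)OC[C@H](CSC[C@@H](N)C(=O)NCCCCCC(=O)O)OC(=O)CCCCCCCCCCC` has not yet been measured. It differs from compound 2 as follows: 5-carboxypentyl in place of 1-methyl-3-phenylpropyl on an amide-type nitrogen. The incoming group has no ring, like the group in compound 1, and again brings a hydrogen-bond donor and acceptor, which the group in compound 2 lacks. Going by the values given here, only the one measured step bears on this, and it points toward lower numbers when the aromatic group is removed, so a drop in this assay is expected, roughly a 3.6-fold lower number from compound 2 to compound 3 (0.55 log units; beyond the scatter). For compound 3 the expected value is 45 nM, with a range from 12 nM to 180 nM.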

Compound 3, half-maximal effective concentration: 108 nM
Beside the measured number, compound 3's estimate is 2.4-fold (0.38 log units) below it, and the stated range covers the measured number.
By their numbers in this assay, from the lowest: compound 1; then compounds 3 and 2 (each within the scatter of the next).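

In this assay the step of a 1.5-fold lower number from compound 2 to compound 3 (0.17 log units; within the scatter) lies within the usual scatter, so compound 2 and compound 3 cannot be told apart, even though 5-carboxypentyl has no ring and brings a hydrogen-bond donor and acceptor that 1-methyl-3-phenylpropyl lacks. On this amide-type nitrogen, then, losing the aromatic ring does not by itself bring the number close to that of compound 1, which also has no ring on this nitrogen. The step of a 4.5-fold higher number from compound 1 to compound 3 (0.65 log units; beyond the scatter) lies beyond the scatter and shows that two ring-free groups can still give clearly different numbers, so the chain and its end matter here as well as the presence or absence of a ring.

Still open, as far as these compounds go, is whether the gap between compound 1 and compound 3 follows the length of the chain or the carboxylic acid at its end, which a longer chain ending in hydroxy or a shorter chain ending in a carboxylic acid could separate. The data shown include no measurement that explains any of these differences.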